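Varying the aryl on the sulfonyl sulfur: towards compound 4

This account rests on a few compounds, and the source may have more. Where it says the series, first, only, none or still open, it means among the compounds named here.

Measured so far in an assay on MDA-MB-231 cells for binding affinity to C-X-C chemokine receptor type 4 (Homo sapiens), read by fluorescence and microscopy, with stated times of 10 min and 30 min; a lower number here means that less compound is needed, a higher number that more compound is needed for the effect:
compound 1 `O=C(NCc1ccc(CNS(=O)(=O)c2cccnc2)cc1)c1ccc(F)cc1` gives 1000 nM
compound 2 `O=C(NCc1ccc(CNS(=O)(=O)c2cccc3ccccc23)cc1)c1ccc(F)cc1` gives 1000 nM
compound 3 `O=C(NCc1ccc(CNS(=O)(=O)c2ccc([N+](=O)[O-])cc2)cc1)c1ccc(F)cc1` gives 1000 nM

Compound 3 stands level with compounds 1 and 2 on the numbers shown; its nearest neighbour is compound 1 and its furthest is compound 2, and neither gap goes beyond the scatter. All three compounds share the same core and differ only in the aryl on the sulfonyl sulfur, whose other neighbour is the sulfonamide nitrogen.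

Compound 4 `O=C(NCc1ccc(CNS(=O)(=O)c2ccc(F)c(F)c2)cc1)c1ccc(F)cc1` is the next member of the set. The change from compound 3 is 3,4-difluorophenyl in place of 4-nitrophenyl on a sulfonyl sulfur.

Within the data shown here, the steps that bear on this are the three exchanges at the same place: no change at the digits printed from compound 1 to compound 2 (within the scatter), no change at the digits printed from compound 1 to compound 3 (within the scatter) and no change at the digits printed from compound 2 to compound 3 (within the scatter). Each of them swaps one aryl for another on the sulfonyl sulfur and none of them moves the value beyond the scatter, so the place appears tolerant to what sits there within this small set. Among the measured compounds shown here, nothing here separates a ring with acceptors from one without, and the 3,4-difluorophenyl has not yet been seen.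

On that basis the step of no change at the digits printed from compound 3 to compound 4 (within the scatter) is expected to stay within the scatter. For compound 4 the estimate in this assay is 1000 nM, with a range from 500 nM to 2000 nM.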

Compound 4, effective concentration (reported as EC, without a stated level of effect): 10 nM
Compound 4: middle estimate off by 100-fold (2.00 log units), on the high side; the measured number lies below the stated range.
By their numbers in this assay, from the lowest: compound 4; then compounds 1, 2 and 3 (each within the scatter of the next).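

In this assay the aryl on the sulfonyl sulfur is shown to matter, which the earlier compounds did not reveal: the exchange for 3,4-difluorophenyl gives a 100-fold lower number from compound 3 to compound 4 (2.00 log units; beyond the scatter) and likewise a 100-fold lower number from compound 2 to compound 4 (2.00 log units; beyond the scatter) and a 100-fold lower number from compound 1 to compound 4 (2.00 log units; beyond the scatter). Among these compounds, the tolerance seen among pyridin-3-yl, naphthalen-1-yl and 4-nitrophenyl therefore holds for those three groups only and does not extend to the whole position, with compound 4 the one member of the set that stands apart from the others. No supporting data are available to connect this difference with any particular feature of the 3,4-difluorophenyl group.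

On these data alone, it remains open whether the lower number needs both fluorines, or whether a phenyl carrying a single fluorine, a plain phenyl or a dichlorophenyl on the sulfonyl sulfur would give a similar value. Also open, as far as these compounds go, is whether a ring carrying an amine or a carboxylic acid would fit the same place, and whether the large step would recur on a core other than the shared core.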